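Cell tolerance notes: the step from compound 2 to compound 4

The source may hold more compounds than are shown below. What is called first, only, known or untested is meant among the compounds shown, and "the series" means these compounds.

Compound 1 `Cc1ccccc1-c1nn(-c2cccc(Cl)c2)cc1CNCCN1CCN(C)CC1`, compound 2 `CN1CCN(CCNCc2cn(-c3ccc(F)cc3F)nc2C2CCCCC2)CC1` and compound 3 `CCOC(=O)Cn1cc(CNCCN2CCN(C)CC2)c(-c2ccccc2C)n1` share one core and have each been run in an ADME assay on Huh-7 cells (Homo sapiens) for cytotoxicity; a higher number here means that more compound is tolerated, a lower number that less compound is tolerated. Compound 1 gives 16000 nM. Compound 2 reaches only the limit of the assay, > 20000 nM, and no number. Compound 3 likewise stops at the limit, > 20000 nM. For the measured compounds named here, the single measured step, an at least 1.2-fold higher number from compound 1 to compound 3 (0.09 log units; that floor lies within the scatter), is itself bounded by the limit of > 20000 nM in this assay, at which 2 of the 3 values shown sit, so compound 2 stands at the ceiling of what the assay reports. Compound 4 `COc1ccc(-c2nn(-c3ccc(F)cc3F)cc2CNCCN2CCN(C)CC2)cc1` differs from compound 2 by 4-methoxyphenyl in place of cyclohexyl on an aromatic carbon. Going by the values given here, no measured step touches this change; the one step available concerns a group on an aromatic nitrogen and is small. The step is expected to be a number no higher from compound 2 to compound 4 (the limit leaves the size open), nothing beyond the scatter. Compound 4 is therefore expected near 20000 nM, within 9000 nM to 45000 nM.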

Compound 4, half-maximal cytotoxic concentration: > 20000 nM
Compound 4 gave a limit, no number; the forecaster's own chance of this, stated with the estimate: 60%; the middle value lies on the limit itself.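

No step can be read from compound 2 to compound 4, since both stop at a limit of the assay and give no number. The compounds shown leave open how 4-methoxyphenyl in place of cyclohexyl alters the result in this assay.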